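Side-Chain Diol to Epoxide: Expected Cell Inhibition

The source may report more compounds than this note shows. Statements on the series, on what has been measured and on what is new or still open speak of the compounds shown alone.

Measured so far in a functional assay on cells (Panel NCI-60 (60 carcinoma cell lines), Homo sapiens) for inhibition; a higher number here means a weaker inhibitor, a lower number a stronger inhibitor:
compound 1, `C[C@H]1CC[C@@]23C1=C[C@@]1(C)CC[C@](C)(C[C@H](O)[C@H](O)[C@@](C)(O)CO)[C@H]1[C@@H]2C[C@@H](O)[C@@H]3C`, gives 18000 nM
compound 2, `C[C@H]1C[C@@H](O)[C@@]23C1=C[C@@]1(C)CC[C@](C)(C[C@H](O)[C@H](O)C(C)(C)O)[C@H]1[C@@H]2CC[C@@H]3C`, gives 18000 nM
compound 3, `C[C@H]1CC[C@@]23C1=C[C@@]1(C)CC[C@](C)(C[C@H](O)[C@H](O)[C@@](C)(O)CO)[C@H]1[C@@H]2CC[C@@H]3C`, gives 18000 nM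

Compound 3 stands level with compound 1 and compound 2 at the digits shown. Among the measured compounds shown here, the one measured step, no change at the digits printed from compound 1 to compound 3 (within the scatter), was flat and concerns a ring carbon, not the side chain. Compound 4, `C[C@H]1CC[C@@]23C1=C[C@@]1(C)CC[C@](C)(C[C@H](O)[C@H](O)C4(C)CO4)[C@H]1[C@@H]2CC[C@@H]3C`, differs from compound 3 in one place: 2-methyloxiran-2-yl in place of 1-hydroxy-1-(hydroxymethyl)ethyl on a saturated chain carbon bound to an oxygen on a saturated carbon and a saturated chain carbon. For the measured compounds named here, no measured step touches this part of the molecule, so nothing points in either direction. Compound 4 is therefore expected to stay close to compound 3 in this assay, and no change at the digits printed from compound 3 to compound 4 (within the scatter) is expected to lie within the scatter. Compound 4 is estimated at 18000 nM, in the range 6000 nM to 45000 nM.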

Compound 4, half-maximal inhibitory concentration: 18000 nM
Compound 4: middle estimate and measured number agree at the digits printed; measured number inside the range.
By their numbers in this assay, from the lowest: compounds 1, 2, 3 and 4 (each within the scatter of the next).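

Among the compounds shown here, at this saturated chain carbon, 2-methyloxiran-2-yl in place of 1-hydroxy-1-(hydroxymethyl)ethyl gives no change at the digits printed from compound 3 to compound 4 (within the scatter) in this assay and is the first measured step to touch the side chain. The end of the chain can thus lose the hydrogen-bond donors of the leaving group and gain a three-membered ring without a readable shift in the value. No supporting measurement bears on why this step is flat. Still open, from the compounds shown here alone, is whether an amine, a carboxylic acid or a longer chain at this place would move the value.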